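Hydroxy to methoxy on the amidine-side benzyl group

The compounds below may be only part of what the source reports. "The series", "measured", "known", "first", "only" and "open" are said of these compounds alone.

Measured compounds in a functional assay on SH-SY5Y cells (Homo sapiens) for cytotoxicity, read by MTT assay, with stated times of 8 h, 30 min and 12 h, tested at 0.5 uM; a lower number here means a weaker effect, a higher number a stronger effect of the compound at the concentration tested:
compound 1 `COc1ccc(CNC(=N)[C@@H]2CCC(=O)N2Cc2ccccc2[N+](=O)[O-])cc1`: 21.1%
compound 2 `COc1ccc(CNC(=N)[C@@H]2CCC(=O)N2Cc2ccc(OC)cc2)cc1`: 24.8%
compound 3 `Cc1ccc(CN2C(=O)CC[C@H]2C(=N)NCc2ccc(O)cc2)cc1`: 21.9%

Compound 3 stands second of the three numbers in this assay; its gap to compound 1 and its gap to compound 2 are both within the scatter, so no order among the three can be claimed.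

Compound 4 `COc1ccc(CNC(=N)[C@@H]2CCC(=O)N2Cc2ccc(C)cc2)cc1` differs from compound 3 by methyl in place of hydrogen on an oxygen on an aromatic ring.

For the measured compounds named here, the only measured step, a number 3.7 percentage points higher from compound 1 to compound 2 (within the scatter), concerns the other benzyl group and was within the scatter; no step in this assay touches the oxygen changed here, and compound 2, which carries the same methoxy group on this side, sits within the scatter of compound 3. For compound 4 the step of a number 1.1 percentage points higher from compound 3 to compound 4 (within the scatter) is therefore expected to stay within the scatter. Compound 4 is estimated at 23%, range 14% to 32%.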

Compound 4, a percentage reported as activity, at one concentration (the size of the read-out at that concentration, not a potency): 21.9%
Compound 4: the middle estimate sits 1.1 percentage points above what was measured; low and high end bracket the measured number.
By their numbers in this assay, from the lowest: compounds 1, 3, 4 and 2 (each within the scatter of the next).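

In this assay, for the compounds shown here, hydroxy to methoxy on this oxygen reads no change at the digits printed from compound 3 to compound 4 (within the scatter) and is the first step measured at this position. The two other steps reaching compound 4 also lie within the scatter: a number 0.8 percentage points higher from compound 1 to compound 4 (within the scatter) with 4-methylphenyl in place of 2-nitrophenyl, and a number 2.9 percentage points lower from compound 2 to compound 4 (within the scatter) with methyl in place of methoxy on an aromatic carbon. No supporting data bear on the reason for these readings.

As far as these compounds go, what a longer chain on this oxygen, or an amine in its place, would do stays open. From the compounds shown here alone, all readings come from a single concentration, so they show only the size of the effect at that concentration, and how the effect would run at other concentrations stays open.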